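This account rests on a few compounds, and the source may have more. Where it says the series, first, only, none or still open, it means among the compounds named here.

Compound 1 `CN(C)c1cccc(C(=O)N[C@H]2CCC[C@H](NC(=O)c3cccc(Cl)c3)C2)c1`: > 10000 nM
Compound 2 `O=C(NC1CCCC2(CN=C(c3cccc(Cl)c3)O2)C1)c1cccnc1`: > 10000 nM

Both were tested in a functional assay on HEK293 cells for antagonist activity at metabotropic glutamate receptor 5 (Homo sapiens), read by FLIPR and calcium flux; on this read-out lower numbers stand for stronger inhibition and higher numbers for weaker inhibition. In this assay compound 1 gives > 10000 nM, which is a limit of the assay rather than a measured number. In this assay compound 2 likewise gives only > 10000 nM, again a limit and not a number. Going by the values given here, compound 2 therefore stands where every value here stands, at the limit of > 10000 nM in this assay, at which 2 of the 2 values shown sit, and no step between measured compounds can be drawn from these two.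

Compound 3 `O=C(NC1CCCC2(CN=C(c3cccc(Cl)c3)O2)C1)c1ccncc1` has not yet been measured. It differs from compound 2 in one place: pyridin-4-yl in place of pyridin-3-yl on a carbonyl carbon. Among the compounds with values here, with no measured step to lean on, and with compound 2 sitting at the limit, no shift beyond the usual scatter is expected from this change, and compound 3 is expected to stay at the limit too. The expected step is a step that the limit leaves unreadable from compound 2 to compound 3. For compound 3 the estimate is 15000 nM, within a range from 5000 nM to 50000 nM.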

Compound 3, half-maximal inhibitory concentration: > 10000 nM
Compound 3 ended at the assay's limit; the forecaster's own chance of this, stated with the estimate: 85%; the middle value is on the limit's open side.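

In this assay compound 2 and compound 3 both give a limit and not a number, so no step can be read between them: the limit of > 10000 nM in this assay, at which 3 of the 3 values shown sit.

Whether pyridin-4-yl and pyridin-3-yl on this carbonyl carbon differ at all stays open, as does how strongly any of these compounds inhibits.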